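The source may report more compounds than this note shows. Statements on the series, on what has been measured and on what is new or still open speak of the compounds shown alone.

For the measured compounds named here, compound 3 `Nc1ccc(C(=O)/C=C/c2ccc3c(c2)B(O)OC3)cc1` sits second highest among the three numbers so far in a functional assay on SK-OV-3 cells (Homo sapiens) for cytotoxicity, read by MTT assay, with a stated time of 48 h; a lower number here means a stronger inhibitor, a higher number a weaker inhibitor: compound 3 gives 20200 nM, close to compound 1 `O=C(/C=C/c1ccc2c(c1)B(O)OC2)c1ccco1`, which gives 20700 nM, while compound 2 `O=C(/C=C/c1ccc2c(c1)B(O)OC2)c1ccc(Br)cc1` gives 4500 nM. Of the measured steps, a 1.0-fold lower number from compound 1 to compound 3 (0.01 log units; within the scatter) and a 4.5-fold higher number from compound 2 to compound 3 (0.65 log units; beyond the scatter) both touch the group on the carbonyl carbon, and one is within the scatter while the other is modest. Compound 4 `O=C(/C=C/c1ccc2c(c1)B(O)OC2)c1cccc(O)c1` differs from compound 3 in one place: 3-hydroxyphenyl in place of 4-aminophenyl on a carbonyl carbon. Going by the values given here, no measured step exchanges an amino group for a hydroxyl, or moves a group around the ring, so the only guide is that swapping the whole aryl group in a 1.0-fold lower number from compound 1 to compound 3 (0.01 log units; within the scatter) left the number unchanged, whereas a 4.5-fold higher number from compound 2 to compound 3 (0.65 log units; beyond the scatter) shifted it modestly. The expected step from compound 3 to compound 4 in this assay is therefore a 1.3-fold lower number from compound 3 to compound 4 (0.13 log units; within the scatter), a small one. Compound 4 is estimated at 15000 nM, with a range from 5000 nM to 45000 nM.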

Compound 4, half-maximal inhibitory concentration: 3800 nM
Compound 4: middle estimate off by 3.9-fold (0.60 log units), on the high side, outside the stated range (below it).
By their numbers in this assay, from the lowest: compounds 4 and 2 (each within the scatter of the next); then compounds 3 and 1 (each within the scatter of the next).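

In this assay, the aryl group on the carbonyl carbon turns out to matter even when the swap keeps the counted features the same: a 5.3-fold lower number from compound 3 to compound 4 (0.73 log units; beyond the scatter) comes from replacing 4-aminophenyl with 3-hydroxyphenyl, which have equal heavy-atom, hydrogen-bond donor and acceptor counts. A step of similar size, a 5.4-fold lower number from compound 1 to compound 4 (0.74 log units; beyond the scatter), separates 3-hydroxyphenyl from furan-2-yl. By contrast, a 1.2-fold lower number from compound 2 to compound 4 (0.07 log units; within the scatter) shows that 3-hydroxyphenyl and 4-bromophenyl cannot be told apart here, although they carry different substituents.

No measurement available here explains these differences. As far as these compounds go, compound 4 changes both the substituent and its ring position in a single step, so the two contributions cannot be separated, and how a carboxylic acid or a methoxy group on that phenyl ring would read remains open.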